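The compounds below may be only part of what the source reports. "The series", "measured", "known", "first", "only" and "open" are said of these compounds alone.

Among the measured compounds shown here, compound 2 `O=C(C1CCOCC1)N1CCc2nc(C#Cc3ccccc3)sc2C1` is the one compound of this small set with a measured number in an assay on HEK293 cells for positive allosteric modulation of metabotropic glutamate receptor 5 (Homo sapiens), read by FLIPR, with a stated time of 1 h; on this read-out higher numbers stand for an effect only at larger amounts of compound and lower numbers for an effect already at smaller amounts: compound 2 gives 290 nM. Compound 1 `O=C(C1CCC1)N1CCc2nc(C#Cc3ccccc3)sc2C1` carries a cyclobutyl group on the carbonyl carbon instead, and in this assay compound 1 gives > 10000 nM, which is a limit of the assay rather than a measured number. The step of an at least 34-fold lower number from compound 1 to compound 2 (1.53 log units; beyond the scatter) is therefore known only as a bound, set by the limit of > 10000 nM in this assay, at which 1 of the 2 values shown sits. Compound 3 `O=C(N1CCCCC1)N1CCc2nc(C#Cc3ccccc3)sc2C1` has not yet been measured. It differs from compound 2 in one place: piperidin-1-yl in place of oxan-4-yl on a carbonyl carbon. For the measured compounds named here, the single measured step that touches this position is the one from compound 1 to compound 2, and it was large, as an at least 34-fold lower number from compound 1 to compound 2 (1.53 log units; beyond the scatter) shows, so a change of ring at the carbonyl carbon can shift the read-out strongly. Whether the direction here is up or down is not settled by the data; a weakening beyond the scatter is expected, with wide uncertainty. In this assay compound 3 is therefore estimated at 2000 nM, most likely between 400 nM and 10000 nM. For compound 3 the expected step is a 6.9-fold higher number from compound 2 to compound 3 (0.84 log units; beyond the scatter).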

Compound 3, half-maximal effective concentration: 75 nM
Compound 3: middle estimate off by 27-fold (1.43 log units), on the high side, and the stated range ends above it.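

As far as these compounds go, the step of a 3.9-fold lower number from compound 2 to compound 3 (0.59 log units; beyond the scatter) in this assay settles the direction that was still open for this swap at the carbonyl carbon: piperidin-1-yl gives a lower number than oxan-4-yl, not a higher one. The two rings are both six-membered and have the same count of heavy atoms, so the read-out at this position responds even to a change of one ring atom and of the atom through which the ring joins the carbonyl, and the hydrogen-bond acceptor counted on oxan-4-yl is not required for a number this low. The wider step an at least 130-fold lower number from compound 1 to compound 3 (2.12 log units; beyond the scatter) is known only as a bound, set by a value that is not a measured number: the limit of > 10000 nM in this assay, at which 1 of the 3 values shown sits.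

The swap changes the ring atom and the point of attachment together, and these compounds do not separate the two. Also open, from the compounds shown here alone, is how a cyclohexyl group, a morpholin-4-yl ring or an open-chain diethylamino group would read on the same carbonyl carbon.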